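The source may report more compounds than this note shows. Statements on the series, on what has been measured and on what is new or still open speak of the compounds shown alone.

Among the two compounds measured in an assay on membranes from liver for displacement of a labelled ligand from Sigma intracellular receptor 2 (Rattus norvegicus), read by scintillation counting, with a stated time of 120 min (a higher number here means a weaker inhibitor, a lower number a stronger inhibitor), compound 2 `Cc1cccc2sc(NC(=O)CCN3CCN(CC4CCCO4)CC3)nc12` holds the higher of the two numbers: compound 2 gives 5000 nM, while compound 1 `CCCCCCN1CCN(CCC(=O)Nc2nc3c(C)cccc3s2)CC1` gives 158 nM. Going by the values given here, the one step between them, a 32-fold higher number from compound 1 to compound 2 (1.50 log units; beyond the scatter), shows how much a change on the saturated chain carbon bound to the ring amine nitrogen can move the result. Compound 3 `Cc1cccc2sc(NC(=O)CCN3CCN(CCN(C(C)C)C(C)C)CC3)nc12` is not yet measured; it alters the same position, with (diisopropylamino)methyl in place of oxolan-2-yl on a saturated chain carbon bound to an amine nitrogen in a ring. Among the compounds with values here, no measured step involves a diisopropylamino group, so the size of the step from compound 1 to compound 2 is the only guide, and it says that this position is sensitive. The expectation is therefore that compound 3 moves back toward a lower number than compound 2, by a 4.2-fold lower number from compound 2 to compound 3 (0.62 log units; beyond the scatter), though with wide uncertainty. Compound 3 is estimated at 1200 nM, within a range from 250 nM to 6000 nM.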

Compound 3, inhibition constant: 121 nM
Compound 3: the middle estimate sits 9.9-fold (1.00 log units) above what was measured; measured number outside the range, below it.
By their numbers in this assay, from the lowest: compounds 3 and 1 (each within the scatter of the next); then compound 2.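

In this assay, the position on the saturated chain carbon bound to an amine nitrogen in a ring can move the number in both directions: the large rise a 32-fold higher number from compound 1 to compound 2 (1.50 log units; beyond the scatter) is matched by a large fall a 41-fold lower number from compound 2 to compound 3 (1.62 log units; beyond the scatter). The second step, a 1.3-fold lower number from compound 1 to compound 3 (0.12 log units; within the scatter), lies within the scatter, so a chain ending in diisopropylamino and the hexyl chain of compound 1 cannot be told apart here, and among these compounds only the oxolan-2-yl group of compound 2 stands apart. No supporting evidence is available to explain why that group differs.

Still open, on these data alone, is whether a smaller amine such as dimethylamino would stay level with compound 3 or move toward compound 2. A methoxy group on the chain could also help show whether the oxygen or the ring of oxolan-2-yl goes with the higher number.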